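Inverted ring stereocentres and oral exposure in the series

The source may hold more compounds than are shown below. What is called first, only, known or untested is meant among the compounds shown, and "the series" means these compounds.

Of the compounds shown here, two have numbers so far. In an ADME assay on the whole organism for pharmacokinetics, with Rattus norvegicus as the target, at a dose of 3 mg/kg by the oral route (a higher number here means that a larger share of the oral dose reaches the circulation, a lower number that a smaller share of the oral dose reaches the circulation), compound 1 `COC(=O)N[C@H](C(=O)N1CCC[C@H]1C(=O)Nc1ccc([C@@H]2CC[C@@H](c3ccc(NC(=O)[C@@H]4CCCN4C(=O)[C@@H](NC(=O)OC)C(C)C)cc3)N2c2ccc(F)cc2)cc1)C(C)C` gives 22% and compound 2 `COC(=O)N[C@H](C(=O)N1CCC[C@H]1C(=O)Nc1ccc([C@@H]2CC[C@@H](c3ccc(NC(=O)[C@@H]4CCCN4C(=O)[C@@H](NC(=O)OC)C(C)(C)C)cc3)N2c2ccc(F)cc2)cc1)C(C)(C)C` gives 23%; these two values lie within the scatter of each other, so compound 2 has the higher figure on paper but is not set apart from compound 1. Going by the values given here, compound 3 `COC(=O)N[C@H](C(=O)N1CCC[C@H]1C(=O)Nc1ccc([C@H]2CC[C@H](c3ccc(NC(=O)[C@@H]4CCCN4C(=O)[C@@H](NC(=O)OC)C(C)(C)C)cc3)N2c2ccc(F)cc2)cc1)C(C)(C)C` is the next member. the two compounds have the same atoms and bonds and differ only in configuration as drawn: 2 of 6 stereo elements differ; a stereocentre at a saturated ring carbon is drawn S in compound 2 and R in compound 3; a stereocentre at a saturated ring carbon is drawn S in compound 2 and R in compound 3 No measured pair shows a step of this kind, so its direction is open; a modest move in this assay either way, or none beyond the scatter, is expected. Compound 3 is expected to give 20%, between 6% and 40%. The expected step is a number 3 percentage points lower from compound 2 to compound 3 (within the scatter).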

Compound 3, oral bioavailability in the Rattus norvegicus assay: 39%
Estimate against measurement, compound 3: 19 percentage points below, and the stated range covers the measured number.
By their numbers in the Rattus norvegicus assay, from the lowest: compounds 1 and 2 (each within the scatter of the next); then compound 3.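

Going by these compounds alone, in the Rattus norvegicus assay, inverting both saturated ring stereocentres gives a number 16 percentage points higher from compound 2 to compound 3 (beyond the scatter), the first step that lies beyond the scatter. In a physicochemical assay for lipophilicity, read by HPLC, at pH 7.4 (a higher number here means a more lipophilic compound, a lower number a more polar compound), compound 2 gives 5.2 and compound 3 gives 5.2, the same figure as printed. The step in oral exposure therefore rests on the configuration at these two centres alone: the fact that compounds 2 and 3 differ only in the configuration as drawn

Open, from the compounds shown here alone, is whether inverting only one of the two centres carries any of this step. Also open, going by these compounds, is whether the full inversion gives a similar step when an amine or a carboxylic acid replaces the fluorine.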